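The compounds below may be only part of what the source reports. "The series", "measured", "known", "first", "only" and "open" are said of these compounds alone.

Of the compounds shown here, three on a shared core have been read in an ADME assay on HepG2 2.2.15 cells (Homo sapiens) for cytotoxicity; on this read-out lower numbers stand for higher toxicity in this test and higher numbers for lower toxicity in this test. Compound 1 `O=CCc1c(-c2ccccc2Cl)c2cc(Cl)ccc2[nH]c1=O`, with formyl on a saturated chain carbon bound to an aromatic carbon, gives 120000 nM. Compound 2 `CC(=O)OCCc1c(-c2ccccc2Cl)c2cc(Cl)ccc2[nH]c1=O`, with acetoxymethyl in that place, gives 27000 nM, and compound 3 `CCC(=O)OCCc1c(-c2ccccc2Cl)c2cc(Cl)ccc2[nH]c1=O`, with (propanoyloxy)methyl, gives 95000 nM. Compound 3 stands level with compound 1, as a 1.3-fold lower number from compound 1 to compound 3 (0.10 log units; within the scatter) shows, and clear of compound 2, as a 3.5-fold higher number from compound 2 to compound 3 (0.55 log units; beyond the scatter) shows. The other measured step, a 4.4-fold lower number from compound 1 to compound 2 (0.65 log units; beyond the scatter), sets compound 2 apart as the lowest of the three.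

Compound 4 `CC(C)C(=O)OCCc1c(-c2ccccc2Cl)c2cc(Cl)ccc2[nH]c1=O` differs from compound 3 by methyl in place of hydrogen on a saturated chain carbon bound to a carbonyl carbon and a saturated chain carbon, so that propanoyloxy becomes (isopropylcarbonyl)oxy. Among the measured compounds shown here, the nearest precedent is a 3.5-fold higher number from compound 2 to compound 3 (0.55 log units; beyond the scatter), a modest rise for a methyl in place of hydrogen on a saturated chain carbon bound to a carbonyl carbon. For the measured compounds named here, that is a single step, however, and no measured compound stands clearly above compound 3, so it cannot be extended with confidence. The expected outcome in this assay is no change beyond the scatter, a 1.1-fold higher number from compound 3 to compound 4 (0.02 log units; within the scatter). For compound 4 the estimated value is 100000 nM, with an expected range from 40000 nM to 220000 nM.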

Compound 4, half-maximal cytotoxic concentration: 62000 nM
The estimate for compound 4 lay 1.6-fold (0.21 log units) above the measured number; the range from low to high includes it.
By their numbers in this assay, from the lowest: compound 2; then compounds 4, 3 and 1 (each within the scatter of the next).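

In this assay, the methyl in place of hydrogen on a saturated chain carbon bound to a carbonyl carbon and a saturated chain carbon, which turns propanoyloxy into (isopropylcarbonyl)oxy, gives a 1.5-fold lower number from compound 3 to compound 4 (0.19 log units; within the scatter), so the clear rise of a 3.5-fold higher number from compound 2 to compound 3 (0.55 log units; beyond the scatter) is not carried on by a further methyl at this place. Compound 4 still stands clear of the acetoxymethyl compound, with a 2.3-fold higher number from compound 2 to compound 4 (0.36 log units; beyond the scatter), and it remains level with the formyl compound, with a 1.9-fold lower number from compound 1 to compound 4 (0.29 log units; within the scatter), which leaves compound 2 as the only one of the four set apart from the rest. Nothing measured on these compounds explains this behaviour of the chain.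

The compounds shown leave open how a longer straight chain such as butanoyl, a tert-butyl group or an amine carried on the same carbonyl carbon would read, and so whether compound 2 is a lone low point or the start of a wider pattern. They also leave open how the free hydroxyl group would read in place of the ester on this chain.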